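Five-Membered Heteroaromatic Ring in Place of a Six-Membered One

The source may hold more compounds than are shown below. What is called first, only, known or untested is meant among the compounds shown, and "the series" means these compounds.

Measured so far in an assay on CHO cells for displacement of a labelled ligand from Substance-P receptor (Homo sapiens); on this read-out lower numbers stand for stronger inhibition and higher numbers for weaker inhibition:
Compound 1 `C[C@@H](O[C@H]1CN2C(=O)C=C(c3cc[n+]([O-])cc3)CC2[C@@H]1c1ccc(F)cc1)c1cc(C(F)(F)F)cc(C(F)(F)F)c1` gives 0.1 nM.
Compound 2 `COc1cc(C2=CC(=O)N3C[C@H](O[C@H](C)c4cc(C(F)(F)F)cc(C(F)(F)F)c4)[C@@H](c4ccc(F)cc4)C3C2)ccn1` gives 1.1 nM.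
Compound 3 `C[C@@H](O[C@H]1CN2C(=O)C=C(c3ccc[n+]([O-])c3)CC2[C@@H]1c1ccc(F)cc1)c1cc(C(F)(F)F)cc(C(F)(F)F)c1` gives 0.15 nM.

Compound 3 stands second highest of the three numbers; its closest neighbour is compound 1, with a 1.5-fold higher number from compound 1 to compound 3 (0.18 log units; within the scatter), and its furthest is compound 2, with a 7.3-fold lower number from compound 2 to compound 3 (0.87 log units; beyond the scatter). Compound 4 `CCc1noc(C2=CC(=O)N3C[C@H](O[C@H](C)c4cc(C(F)(F)F)cc(C(F)(F)F)c4)[C@@H](c4ccc(F)cc4)C3C2)n1` alters the ring attached to the shared core: a group of 7 heavy atoms (4 carbon, 2 nitrogen, 1 oxygen; one five-membered aromatic ring with 3 hetero atoms) in place of a group of 7 heavy atoms (5 carbon, 1 nitrogen, 1 oxygen; one six-membered aromatic ring with 1 hetero atom), on a double-bonded ring carbon. Within the data shown here, no measured step swaps a six-membered ring for a five-membered one at this position, so the guides are indirect: the small step of a 1.5-fold higher number from compound 1 to compound 3 (0.18 log units; within the scatter) and the larger step of an 11-fold higher number from compound 1 to compound 2 (1.04 log units; beyond the scatter), both at the same place. Some weakening beyond the scatter is expected: a 4.0-fold higher number from compound 3 to compound 4 (0.60 log units; beyond the scatter). Compound 4 is therefore estimated at 0.6 nM in this assay, within 0.12 nM to 3 nM.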

Compound 4, half-maximal inhibitory concentration: 0.4 nM
Compound 4: middle estimate off by 1.5-fold (0.18 log units), on the high side, and the stated range covers the measured number.
By their numbers in this assay, from the lowest: compounds 1 and 3 (each within the scatter of the next); then compound 4; then compound 2.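

With 3-ethyl-1,2,4-oxadiazol-5-yl on the double-bonded ring carbon, a five-membered aromatic ring is now seen at this position, and it gives weaker inhibition than the six-membered rings of two compounds: a 2.7-fold higher number from compound 3 to compound 4 (0.43 log units; beyond the scatter) and a 4.0-fold higher number from compound 1 to compound 4 (0.60 log units; beyond the scatter) in the same direction. It still outperforms 2-methoxypyridin-4-yl, with a 2.8-fold lower number from compound 2 to compound 4 (0.44 log units; beyond the scatter) on this read-out, so compound 2 shows that ring size alone does not set the order. Nothing available explains these steps. Still open, as far as these compounds go, is what the ethyl chain contributes, and whether a methyl group, an amine or a longer chain in its place would shift the number.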